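Swapping Chloro for Amino on a Purine-like Core

The source may hold more compounds than are shown below. What is called first, only, known or untested is meant among the compounds shown, and "the series" means these compounds.

Of the compounds shown here, two have so far been tested in a functional assay on HOP-62 cells (Homo sapiens) for cytotoxicity, read by sulforhodamine B assay, with a stated time of 48 h; on this read-out higher numbers stand for lower toxicity in this test and lower numbers for higher toxicity in this test. Compound 1, whose structure is `ClCc1ccccc1Cn1cnc2c(Cl)nc(Cl)nc21`, gives 6450 nM in this assay. Compound 2, with the structure `ClCc1cccc(Cn2cnc3c(Cl)ncnc32)c1`, gives 10200 nM. Compound 1 thus has the lowest of the two numbers, yet the gap to compound 2 lies within the usual scatter of this kind of measurement, so the two results cannot be told apart.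

Compound 3, with the structure `Nc1nc(Cl)c2ncn(Cc3ccccc3CCl)c2n1`, has not yet been measured. It differs from compound 1 in a single place: amino in place of chloro on an aromatic carbon. The carbon carrying the change sits between two ring nitrogen atoms of the six-membered ring, meta to a chloro group. Among the compounds with values here, no pair of measured compounds shows what such a swap does here, so there is no step to lean on.

The expectation is therefore cautious: the step from compound 1 to compound 3 is estimated to be small, a 1.2-fold higher number from compound 1 to compound 3 (0.09 log units; within the scatter), and not clearly beyond the scatter in either direction. For compound 3 the estimated value in this assay is 8000 nM, with a range from 2500 nM to 25000 nM.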

Compound 3, concentration lethal to 50% of the cells: > 100000 nM
Compound 3: a limit, no number; the forecaster's own chance of this, stated with the estimate: 10%; middle value at least 12-fold (1.09 log units) from the limit.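

On the aromatic carbon between two ring nitrogen atoms, swapping chloro for amino is far from a neutral change in this assay: the swap gives an at least 15-fold higher number from compound 1 to compound 3 (1.19 log units; beyond the scatter). Compound 3 stands at a limit of the assay rather than at a number, so the step has a floor but no known size: the limit of > 100000 nM in this assay, at which 1 of the 3 values shown sits. Within the data shown here, until now, no measured pair showed what any single swap does on this core; this pair shows that replacing one chlorine atom with one nitrogen atom at this carbon can move the result well beyond the scatter, towards lower toxicity in this test.

This one swap cannot tell whether the loss of chloro or the arrival of amino matters more, or whether the same holds for the other chloro group, which sits meta to this carbon. A methoxy group, a hydroxyl group or a methylamino group on the same carbon would show how far the result depends on chloro leaving and how far on the particular group that enters.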